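Chloro for fluoro on the shared core

The source may hold more compounds than are shown below. What is called first, only, known or untested is meant among the compounds shown, and "the series" means these compounds.

Compound 1 `CCCNNC(=O)c1ccc(CNC(=O)c2cc3ccccc3o2)cc1`: > 10000 nM
Compound 2 `CCCNNC(=O)c1ccc(CNC(=O)c2cc3cc(F)ccc3o2)cc1`: > 10000 nM

In an assay on isolated protein for inhibition of protein deacetylase HDAC6 (Homo sapiens), read by fluorescence, with a stated time of 2 h (on this read-out lower numbers stand for stronger inhibition and higher numbers for weaker inhibition), compound 1 gives > 10000 nM, which is a limit of the assay rather than a number. Compound 2 gives > 10000 nM in this assay, again a limit. The step that the two limits leave unreadable from compound 1 to compound 2 therefore cannot be sized, because of the limit of > 10000 nM in this assay, at which 2 of the 2 values shown sit. Compound 3 `CCCNNC(=O)c1ccc(CNC(=O)c2cc3cc(Cl)ccc3o2)cc1` carries chloro in place of fluoro on an aromatic carbon. Going by the values given here, no measured step bears on this change, and compound 2 stands at a limit, so no shift beyond the scatter is expected; compound 3 is estimated at 15000 nM with a range from 5000 nM to 50000 nM, a step that the limit leaves unreadable from compound 2 to compound 3 that is expected to leave it at the limit.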

Compound 3, half-maximal inhibitory concentration: > 10000 nM
Compound 3: no number, only a limit; the forecaster's own chance of this, stated with the estimate: 80%; the middle value does not contradict the limit.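

Going by these compounds alone, no step among compound 1, compound 2 and compound 3 can be read in this assay because all three stand at the same limit: the limit of > 10000 nM in this assay, at which 3 of the 3 values shown sit.
The compounds shown leave open whether hydrogen, fluoro or chloro on the shared core makes any difference to inhibition.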